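The compounds below may be only part of what the source reports. "The series", "measured", "known", "first", "only" and "open" are said of these compounds alone.

Compound 3 `N#CC1=C(NC(=O)CCC(=O)O)N(c2ccc(S(N)(=O)=O)cc2)C2=C(C(=O)CCC2)C1c1ccc(Cl)cc1Cl` gives 50% in a functional assay on Ehrlich cells (Mus musculus) for cytotoxicity, read by trypan blue exclusion, with a stated time of 2 h, tested at 50 ug/mL (a lower number here means a weaker effect, a higher number a stronger effect of the compound at the concentration tested), the second highest of the three numbers. Compound 1 `C=CCNC(=S)NC1=C(C#N)C(c2ccc(Cl)cc2Cl)C2=C(CCCC2=O)N1c1ccc(S(N)(=O)=O)cc1` gives 33%, a step of a number 17 percentage points higher from compound 1 to compound 3 (beyond the scatter), while compound 2 `N#CC1=C(NC(=S)Nc2ccc(Br)cc2)N(c2ccc(S(N)(=O)=O)cc2)C2=C(C(=O)CCC2)C1c1ccc(Cl)cc1Cl` gives 90%, a step of a number 40 percentage points lower from compound 2 to compound 3 (beyond the scatter). Compound 4 `N#CC1=C(NS(=O)(=O)c2ccc([N+](=O)[O-])cc2)N(c2ccc(S(N)(=O)=O)cc2)C2=C(C(=O)CCC2)C1c1ccc(Cl)cc1Cl` differs from compound 3 in one place: (4-nitrophenyl)sulfonyl in place of (2-carboxyethyl)carbonyl on an amine nitrogen. Among the measured compounds shown here, two measured steps bear on this change. One is a number 57 percentage points higher from compound 1 to compound 2 (beyond the scatter); the other is a number 40 percentage points lower from compound 2 to compound 3 (beyond the scatter). In both, the compound carrying an aromatic ring on the amine nitrogen gave the higher number, so an aromatic ring entering at that nitrogen is expected to raise the number again. A rise beyond the scatter is therefore expected for compound 4, estimated as a number 22 percentage points higher from compound 3 to compound 4 (beyond the scatter). Compound 4 is expected to give about 72%, within a range from 45% to 92%.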

Compound 4, a percentage reported as activity, at one concentration (the size of the read-out at that concentration, not a potency): 85%
The estimate for compound 4 lay 13 percentage points below the measured number, within the range that was stated.
By their numbers in this assay, from the lowest: compound 1; then compound 3; then compounds 4 and 2 (each within the scatter of the next).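

In this assay, replacing (2-carboxyethyl)carbonyl with (4-nitrophenyl)sulfonyl gives a number 35 percentage points higher from compound 3 to compound 4 (beyond the scatter), so an aromatic ring on this amine nitrogen goes with a high number through a sulfonyl link too, not only through the thiourea of compound 2. The comparison with that thiourea gives a number 5 percentage points lower from compound 2 to compound 4 (within the scatter), while the comparison with the allyl thiourea gives a number 52 percentage points higher from compound 1 to compound 4 (beyond the scatter). No measurement here explains these steps. Still open, going by these compounds, is whether the ring or the sulfonyl link matters more: a methylsulfonyl group has the link without the ring. A plain phenylsulfonyl group would likewise test the role of the nitro group.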